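A few compounds are considered here, and "the series" means these few. Any claim that something is new, unique, unknown or untested is made for them only; others in the source may bear on it.

Measured compounds:
compound 1 `Cc1cccc(-c2cc(-c3ccc(Cl)o3)cc(-c3ccsc3)n2)c1`, 20200 nM
compound 2 `Clc1ccc(-c2cc(-c3cccnc3)nc(-c3cccs3)c2)o1`, 22300 nM
compound 3 `Cc1ccccc1-c1cc(-c2ccc(Cl)o2)cc(-c2ccsc2)n1`, 18400 nM

All three were tested in a functional assay on K562 cells (Homo sapiens) for cytotoxicity, in the presence of a further agent that is not named here; a lower number here means a stronger inhibitor, a higher number a weaker inhibitor. Compound 2 gives the highest of the three numbers, but its neighbours sit close: compound 1 lies a small distance below it and compound 3 a little further, both gaps within the scatter, so no ordering among the three can be claimed. For the measured compounds named here, the only single-point step on record, a 1.1-fold lower number from compound 1 to compound 3 (0.04 log units; within the scatter), swaps the methylphenyl pattern at the position next to the ring nitrogen and changes nothing beyond the scatter.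

Compound 4 `Clc1ccc(-c2cc(-c3cccs3)nc(-c3ccccc3Cl)c2)o1` has not yet been measured. It differs from compound 2 as follows: 2-chlorophenyl in place of pyridin-3-yl on an aromatic carbon. This is the same position that varies between compound 1 and compound 3, where a six-membered carbon-only ring already stands in both, and there the numbers stayed flat. Compound 2, carrying the pyridin-3-yl group at that place, gives a value indistinguishable from those two. On this basis the step of a 1.2-fold lower number from compound 2 to compound 4 (0.07 log units; within the scatter) is expected to fall within the scatter, with no direction favoured. Compound 4 is therefore estimated at 19000 nM, with a range from 8000 nM to 45000 nM, in this assay.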

Compound 4, half-maximal inhibitory concentration: 17200 nM
Compound 4: middle estimate off by 1.1-fold (0.04 log units), on the high side; the measured number falls inside the stated range.
By their numbers in this assay, from the lowest: compounds 4, 3, 1 and 2 (each within the scatter of the next).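

In this assay, the swap of pyridin-3-yl for 2-chlorophenyl at the position next to the ring nitrogen gives a 1.3-fold lower number from compound 2 to compound 4 (0.11 log units; within the scatter). The earlier step only moved a methyl group around a phenyl ring, whereas this one replaces a ring that holds a nitrogen and carries a hydrogen-bond acceptor with a carbon-only ring that has no acceptor and brings in a chlorine, and even so the two numbers cannot be told apart. On the core with thiophen-2-yl and 5-chlorofuran-2-yl, then, this place tolerates that exchange of ring type and added chlorine without a readable shift in the cytotoxicity read-out, though nothing available here bears on why that should be so.

Every group shown at this position is a six-membered aromatic ring, and all four compounds lie within the scatter of their neighbours in the ranking, so it remains open whether anything placed here can move the number beyond the scatter. An amine, a carboxylic acid or a longer alkyl chain at this position would test that, and the same question stands for the thiophene and 5-chlorofuran-2-yl positions.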